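The source may report more compounds than this note shows. Statements on the series, on what has been measured and on what is new or still open speak of the compounds shown alone.

Measured compounds:
Compound 1, `O=C(CSc1nc(Nc2ccccc2)c2ccccc2n1)Nc1cccc([N+](=O)[O-])c1`, in a functional assay on MGC-803 cells (Homo sapiens) for inhibition, read by MTT assay, with a stated time of 72 h (on this read-out lower numbers stand for stronger inhibition and higher numbers for weaker inhibition), compound 1 gives 28100 nM.
Compound 2, `C=CC(=O)Nc1cccc(NC(=O)CSc2nc(Nc3cccc(F)c3)c3ccccc3n2)c1`, in this assay compound 2 gives 6250 nM.

Of the two numbers shown, compound 2 has the lower one, and its distance from compound 1 lies beyond the usual scatter of repeated measurements. Compound 3, `C=CC(=O)Nc1cccc(NC(=O)CSc2nc(Nc3ccc(C(F)(F)F)cc3)c3ccccc3n2)c1`, has not yet been measured. It differs from compound 2 in one place: 4-(trifluoromethyl)phenyl in place of 3-fluorophenyl on a nitrogen on an aromatic ring. Among the compounds with values here, nothing among the measured compounds isolates this change, so the size of the step cannot be read from a comparable pair. For compound 3 the step of a 1.3-fold higher number from compound 2 to compound 3 (0.11 log units; within the scatter) is expected to fall within the scatter, with no clear direction. The estimate for compound 3 in this assay is 8000 nM, with a range from 2500 nM to 25000 nM.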

Compound 3, half-maximal inhibitory concentration: 12100 nM
Compound 3: middle estimate off by 1.5-fold (0.18 log units), on the low side; the measured number falls inside the stated range.
By their numbers in this assay, from the lowest: compounds 2 and 3 (each within the scatter of the next); then compound 1.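

In this assay, within the data shown here, the exchange of 3-fluorophenyl for 4-(trifluoromethyl)phenyl on the nitrogen gives a 1.9-fold higher number from compound 2 to compound 3 (0.29 log units; within the scatter), the first step that can be read at this position. The position therefore accepts the larger 4-(trifluoromethyl)phenyl group with no separation from 3-fluorophenyl beyond the scatter, although this single step changes both the substituent and where it sits on the ring, and cannot tell those two changes apart. Nothing measured here explains this outcome.

As far as these compounds go, whether a dimethylamino group or a carboxylic acid in place of the trifluoromethyl would keep the number in this range remains open. Among these compounds, compound 1 differs from compound 2 and compound 3 in more than one place, so no step to it can be read.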